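Methoxy removal in a bromophenol chalcone series and a fused analog

The source may report more compounds than this note shows. Statements on the series, on what has been measured and on what is new or still open speak of the compounds shown alone.

Compound 1 `COc1cc(Br)cc(/C=C/C(=O)c2ccc(C)cc2)c1O` gives 61.5% in a functional assay on MCF7 cells (Homo sapiens) for antiproliferative activity, read by sulforhodamine B assay, with a stated time of 72 h, tested at 30 uM; a higher number here means a weaker effect of the compound at the concentration tested, a lower number a stronger effect. Compound 2 `Cc1ccc(C(=O)/C=C/c2cc(Br)ccc2O)cc1` gives 31.8% in this assay. The two differ by hydrogen in place of methoxy on an aromatic carbon, and the step is a number 29.7 percentage points lower from compound 1 to compound 2 (beyond the scatter). Compound 3 `COC(=O)C1=C(N)Oc2c(OC)cc(Br)cc2C1CC(=O)c1ccc(Br)cc1` gives 31.9% in this assay; the difference between the core of compound 3 and that of compound 1 is not broken down here. Compound 4 `COC(=O)C1=C(N)Oc2ccc(Br)cc2C1CC(=O)c1ccc(Br)cc1` is not yet measured and differs from compound 3 by hydrogen in place of methoxy on an aromatic carbon. This is the same kind of change as that from compound 1 to compound 2, though the place differs: in compound 1 the carbon is ortho to a hydroxy group and meta to a large group, in compound 3 it is ortho to a fused ring and meta to a fused ring. Because a number 29.7 percentage points lower from compound 1 to compound 2 (beyond the scatter) started from a higher value than compound 3 shows, a smaller lowering is expected here. For compound 4 the expected step is a number 10.9 percentage points lower from compound 3 to compound 4 (beyond the scatter). Compound 4 is thus estimated at 21%, with a range from 6% to 40%.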

Compound 4, a percentage reported as activity, at one concentration (the size of the read-out at that concentration, not a potency): 34.8%
The estimate for compound 4 lay 13.8 percentage points below the measured number, within the range that was stated.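

In this assay, hydrogen in place of methoxy on an aromatic carbon gives a number 2.9 percentage points higher from compound 3 to compound 4 (within the scatter), so compound 3 and compound 4 cannot be told apart. The step seen on the core of compound 1 does not carry over to the core of compound 3: the same change on two cores in this assay, a number 29.7 percentage points lower (beyond the scatter) from compound 1 to compound 2 and a number 2.9 percentage points higher (within the scatter) from compound 3 to compound 4, 32.6 percentage points apart, beyond the scatter of two such steps. This shows that the size of the step depends on the core for these two pairs, but it does not show which difference between the cores is responsible or how the change would read on a further core.

Going by these compounds, it remains open how an amine or a carboxylic acid in place of methoxy on this aromatic carbon would read on either core. Also open, on these data alone, is whether the gap between the two steps would hold at another concentration.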